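A few compounds are considered here, and "the series" means these few. Any claim that something is new, unique, unknown or untested is made for them only; others in the source may bear on it.

Measured so far in a functional assay on SGC-7901 cells (Homo sapiens) for inhibition, read by MTT assay, with a stated time of 24 h; on this read-out higher numbers stand for weaker inhibition and lower numbers for stronger inhibition:
- compound 1 `COc1ccccc1-n1cc(CN2C(=O)C[C@@H]3CC[C@@]2(C)C3(C)C)nn1` gives 280 nM
- compound 2 `CC1(C)[C@H]2CC[C@]1(C)N(Cc1cn(-c3ccccc3)nn1)C(=O)C2` gives 240 nM
- compound 3 `Cc1ccc(-n2cc(CN3C(=O)C[C@@H]4CC[C@@]3(C)C4(C)C)nn2)cc1` gives 390 nM

Compound 3 does not stand apart from the other two, with a 1.4-fold higher number from compound 1 to compound 3 (0.14 log units; within the scatter) and a 1.6-fold higher number from compound 2 to compound 3 (0.21 log units; within the scatter) on record.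

Next is compound 4 `CC1(C)[C@H]2CC[C@]1(C)N(Cc1cn(-c3ccccc3O)nn1)C(=O)C2` which carries 2-hydroxyphenyl in place of 4-methylphenyl on an aromatic nitrogen. The closest measured change at that nitrogen is a 1.4-fold higher number from compound 1 to compound 3 (0.14 log units; within the scatter) where 4-methylphenyl replaces 2-methoxyphenyl. The two single changes on the aromatic ring, a 1.2-fold lower number from compound 1 to compound 2 (0.07 log units; within the scatter) and a 1.6-fold higher number from compound 2 to compound 3 (0.21 log units; within the scatter) are equally small. Among the measured compounds shown here, no compound with a hydroxyl group has been measured, so the effect of that group remains open.

Across these three compounds, no change of the group on that nitrogen gives a step beyond the scatter, and none is expected here in this assay in either direction. The working guess leans toward compound 1 at 280 nM as the other measured compound with a 2-substituted phenyl. The estimated step is a 1.4-fold lower number from compound 3 to compound 4 (0.14 log units; within the scatter) and would stay within the scatter. The expected value for compound 4 is 280 nM with an estimated range of 120 nM to 650 nM as its ends.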

Compound 4, half-maximal inhibitory concentration: 410 nM
Compound 4: middle estimate off by 1.5-fold (0.17 log units), on the low side, within the range that was stated.
By their numbers in this assay, from the lowest: compounds 2, 1, 3 and 4 (each within the scatter of the next).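

In this assay, the exchange of 4-methylphenyl for 2-hydroxyphenyl on the aromatic nitrogen brings in a hydrogen-bond donor and a hydrogen-bond acceptor, yet the result is a 1.1-fold higher number from compound 3 to compound 4 (0.02 log units; within the scatter) and the series shows no response to this change. The hydroxyl can now also be read against the two closest groups: hydroxy on the unsubstituted phenyl gives a 1.7-fold higher number from compound 2 to compound 4 (0.23 log units; within the scatter) in this comparison, and loss of the methyl from the oxygen of the methoxy group gives a 1.5-fold higher number from compound 1 to compound 4 (0.17 log units; within the scatter) for the free hydroxyl. A free hydroxyl on this aromatic ring therefore joins methoxy, methyl and hydrogen as a change that stays within the scatter, and no information is available on what lies behind this flat picture.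

Still open, on these data alone, is whether any group on this phenyl ring moves the number beyond the scatter, for example an amine, a carboxylic acid or a longer alkoxy chain. Also open, as far as these compounds go, is whether replacing the phenyl on the aromatic nitrogen with a benzyl or a pyridyl group, or changing the shared core, would separate compounds in this read-out.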